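The source may hold more compounds than are shown below. What is called first, only, known or untested is meant among the compounds shown, and "the series" means these compounds.

Measured so far:
Compound 1, `O=C(CSc1nc(Nc2ccccc2)c2ccccc2n1)Nc1cccc(Cl)c1`, gives 16500 nM in a functional assay on MDA-MB-231 cells (Homo sapiens) for inhibition, read by MTT assay, with a stated time of 72 h; a lower number here means a stronger inhibitor, a higher number a weaker inhibitor.
Compound 2, `C=CC(=O)Nc1cccc(NC(=O)CSc2nc(Nc3ccccc3)c3ccccc3n2)c1`, gives 10200 nM in this assay.

Compound 2 stands at the lower of the two numbers shown, but a 1.6-fold lower number from compound 1 to compound 2 (0.21 log units; within the scatter) lies within the scatter, so the two compounds are not told apart. Compound 3, `C=CC(=O)Nc1cccc(NC(=O)CSc2nc(Nc3ccc(CC)cc3)c3ccccc3n2)c1`, differs from compound 2 by ethyl in place of hydrogen on an aromatic carbon, turning anilino into (4-ethylphenyl)amino. Among the measured compounds shown here, the only measured step alters a group elsewhere on the core and does not bear on this change. The step of a 1.1-fold lower number from compound 2 to compound 3 (0.03 log units; within the scatter) is therefore expected to stay within the scatter. Compound 3 is estimated at 9500 nM, between 4000 nM and 25000 nM.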

Compound 3, half-maximal inhibitory concentration: 14400 nM
Beside the measured number, compound 3's estimate is 1.5-fold (0.18 log units) below it; the measured number falls inside the stated range.
By their numbers in this assay, from the lowest: compounds 2, 3 and 1 (each within the scatter of the next).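

Turning anilino into (4-ethylphenyl)amino gives a 1.4-fold higher number from compound 2 to compound 3 (0.15 log units; within the scatter) in this assay and so leaves the two compounds untold apart. Among the compounds shown here, this is the first reading at this part of the molecule: on this aromatic carbon, para to a large group, ethyl gives no difference that the assay can resolve from hydrogen. No measurement at hand offers an explanation for this result. Going by these compounds, with only hydrogen and ethyl compared here, it remains open whether a longer chain, an amine or a carboxylic acid on this carbon would produce a step beyond the scatter.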